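Aryl ester to furanyl ester on the shared core

The source may report more compounds than this note shows. Statements on the series, on what has been measured and on what is new or still open speak of the compounds shown alone.

Among the measured compounds shown here, compound 1 `CC1=CC[C@H]2[C@@H]1CC=C(C)[C@@H](CC[C@H]1[C@]3(C)CC[C@H](OC(=O)CCC(=O)O)C(C)(C)O[C@H]3CC[C@@]1(C)O)C2(C)C` is one of two compounds measured in a functional assay on MCF7 cells (Homo sapiens) for antiproliferative activity, read by MTT assay, with a stated time of 72 h; a higher number here means a weaker inhibitor, a lower number a stronger inhibitor; in that assay compound 1 reaches only > 50000 nM, which is a limit of the assay and not a number. The series therefore holds a single real value (the limit of > 50000 nM in this assay, at which 1 of the 2 values shown sits). Compound 2 `CC1=CC[C@H]2[C@H](CC[C@]2(C)O)C(C)(C)[C@@H]1CC[C@H]1[C@]2(C)CC[C@H](OC(=O)c3ccc(F)cc3)C(C)(C)O[C@H]2CC[C@@]1(C)O` provides it: in this assay compound 2 gives 33500 nM, the only number shown.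

Compound 3 `CC1=CC[C@H]2[C@H](CC[C@]2(C)O)C(C)(C)[C@@H]1CC[C@H]1[C@]2(C)CC[C@H](OC(=O)c3ccco3)C(C)(C)O[C@H]2CC[C@@]1(C)O` has not yet been measured. It differs from compound 2 in one place only: furan-2-yl in place of 4-fluorophenyl on a carbonyl carbon. For the measured compounds named here, no step between two measured compounds is available, so nothing sets the size of this change. The expectation is a step not beyond the usual scatter, with no clear direction; the step that the estimate means is a 1.1-fold lower number from compound 2 to compound 3 (0.05 log units; within the scatter). Compound 3 is accordingly expected near 30000 nM, in a range from 12000 nM to 75000 nM, with some chance that only a limit is reported.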

Compound 3, half-maximal inhibitory concentration: 25700 nM
Compound 3: middle estimate off by 1.2-fold (0.07 log units), on the high side, within the range that was stated.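

In this assay, the first step read at this position is a 1.3-fold lower number from compound 2 to compound 3 (0.12 log units; within the scatter), so furan-2-yl and 4-fluorophenyl on a carbonyl carbon cannot be told apart in this read-out. Replacing one six-membered aromatic ring of carbon only with one five-membered aromatic ring with 1 hetero atom, which also brings in 1 hydrogen-bond acceptor, therefore leaves the result within the scatter on the shared core. Nothing shown bears on why these two esters read alike.

Among the compounds shown here, compound 1 gives > 50000 nM, which is a limit of the assay and not a number, so no step to it can be read. Going by these compounds, whether an aminophenyl group, a pyridine ring or a longer alkyl chain on this carbonyl carbon would produce a step beyond the scatter remains open.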